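Swapping Chloro for Cyano on the Benzamide Ring

The source may report more compounds than this note shows. Statements on the series, on what has been measured and on what is new or still open speak of the compounds shown alone.

Compound 3 `O=C(Nc1ccc(NS(=O)(=O)C(F)(F)F)c(F)c1)c1ccc(Cl)cc1` gives 3270 nM in this study. Compound 1 `COc1cc(NC(=O)c2ccc(C#N)cc2)ccc1NS(=O)(=O)C(F)(F)F` gives > 250000 nM, which is a limit of the assay and not a number. Compound 2 `CS(=O)(=O)Nc1ccc(NC(=O)c2ccc(C#N)cc2)cc1F` likewise gives > 250000 nM, again a limit rather than a number.

Among the compounds with values here, in an ADME assay on RAW264.7 cells (Mus musculus) for cytotoxicity, read by MTT assay, with a stated time of 48 h (a lower number here means a stronger inhibitor, a higher number a weaker inhibitor), compound 3 therefore stands as the only actual number among the three measured compounds, the other two results being limits. Compound 4 `N#Cc1ccc(C(=O)Nc2ccc(NS(=O)(=O)C(F)(F)F)c(F)c2)cc1` differs from compound 3 in one place: cyano in place of chloro on an aromatic carbon. Within the data shown here, no step between two measured compounds is available to guide this change. Because the limit of > 250000 nM in this assay, at which 2 of the 3 values shown sit, covers compound 1 and compound 2, which both carry the nitrile, a weakening beyond the scatter is expected, although those two compounds also differ from compound 4 elsewhere. Compound 4 is expected to give 25000 nM, between 4000 nM and 200000 nM, a step of a 7.6-fold higher number from compound 3 to compound 4 (0.88 log units; beyond the scatter) that may end at the limit.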

Compound 4, half-maximal inhibitory concentration: > 250000 nM
Compound 4: no number, only a limit; the forecaster's own chance of this, stated with the estimate: 40%; middle value at least 10-fold (1.00 log units) away from the limit.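

The earlier compounds shown here carried the nitrile but differed from compound 3 elsewhere too, so they could not isolate this change. Compound 4 does: in this assay, cyano in place of chloro on the benzamide ring, with nothing else altered, gives an at least 76-fold higher number from compound 3 to compound 4 (1.88 log units; beyond the scatter). From the compounds shown here alone, the result for compound 4 is a limit and not a number, so the full size of this step stays unknown, and it joins the other such results: the limit of > 250000 nM in this assay, at which 3 of the 4 values shown sit.

The steps from compound 2 and from compound 1 to compound 4 join two limits and cannot be read. Going by these compounds, whether a methyl group or an amine in this place would sit nearer to chloro or to cyano stays open.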